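The source may hold more compounds than are shown below. What is called first, only, known or untested is meant among the compounds shown, and "the series" means these compounds.

In a toxicity assay on THP-1 cells (Homo sapiens) for inhibition (on this read-out lower numbers stand for higher toxicity in this test and higher numbers for lower toxicity in this test), compound 1 `Cn1c(-c2ccccc2Cl)cnc1NC(=O)c1ccc(F)cc1` reads > 50000 nM, which is a limit. Compound 2 `Cn1c(-c2ccc(Cl)cc2)cnc1NC(=O)c1ccc(F)cc1` gives a measured 37000 nM. Compound 3 `Cn1c(-c2cccc(C#N)c2)cnc1NC(=O)c1ccc(F)cc1` reads > 100000 nM, also a limit and the highest figure shown. Compound 4 `COc1ccccc1-c1cnc(NC(=O)c2ccc(F)cc2)n1C` differs from it by 2-methoxyphenyl in place of 3-cyanophenyl on an aromatic carbon. Among the measured steps, the change gave an at least 2.7-fold higher number from compound 2 to compound 3 (0.43 log units; beyond the scatter), whereas the other two gave an at least 1.3-fold lower number from compound 1 to compound 2 (0.13 log units; that floor lies within the scatter) and a step that the two limits leave unreadable from compound 1 to compound 3. Compound 1, bearing 2-chlorophenyl, is the closest guide to the entering 2-methoxyphenyl, so a number near its limit of > 50000 nM is expected. The expected change is modest and downward, namely an at least 1.6-fold lower number from compound 3 to compound 4 (0.22 log units; that floor lies within the scatter). Compound 4 is estimated at 60000 nM, with an expected range of 25000 nM to 150000 nM.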

Compound 4, half-maximal cytotoxic concentration: > 100000 nM
Compound 4: only a limit was reported; the forecaster's own chance of this, stated with the estimate: 55%; middle value at least 1.6-fold (0.22 log units) from the limit.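

In this assay, 2-methoxyphenyl in compound 4 reaches the same limit as 3-cyanophenyl in compound 3, so this upper limit is not confined to the group with the nitrile: the limit of > 100000 nM in this assay, at which 2 of the 4 values shown sit. Putting 2-methoxyphenyl in place of 4-chlorophenyl gives an at least 2.7-fold higher number from compound 2 to compound 4 (0.43 log units; beyond the scatter), and only compound 2 has a measured number rather than a limit. The steps to compound 4 from compound 1 and from compound 3 cannot be read.

On these data alone, how far compound 1, compound 3 and compound 4 lie beyond their limits remains open. Also open, as far as these compounds go, is what an amine or a carboxylic acid on this phenyl ring would give.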